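A few compounds are considered here, and "the series" means these few. Any claim that something is new, unique, unknown or untested is made for them only; others in the source may bear on it.

Compound 1 `Nc1nc2c(c(-c3ccccc3)cn2[C@@H]2O[C@H](CO)[C@@H](O)[C@H]2O)c(=O)[nH]1` bears a phenyl group on the shared core. In a functional assay on K562 cells (Homo sapiens), read by MTT assay, with a stated time of 72 h (on this read-out higher numbers stand for weaker inhibition and lower numbers for stronger inhibition), compound 1 gives > 20000 nM, which is a limit of the assay and not a number. Compound 2 `CNc1ncnc2c1c(-c1cc3ccccc3o1)cn2[C@@H]1O[C@H](CO)[C@@H](O)[C@H]1O` differs from compound 1 in more than one place. In this assay compound 2 gives > 20000 nM, again a limit rather than a number. Compound 1 therefore stands at the same limit as every other value shown; the evidence is simply (the limit of > 20000 nM in this assay, at which 2 of the 2 values shown sit).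

Compound 3 `Nc1nc2c(c(-c3ccoc3)cn2[C@@H]2O[C@H](CO)[C@@H](O)[C@H]2O)c(=O)[nH]1` has not yet been measured. It differs from compound 1 by one change: furan-3-yl in place of phenyl on an aromatic carbon. For the measured compounds named here, no step between two measured compounds is available, so the size of this change has no measured counterpart in the data. Because compound 1 sits at > 20000 nM, a limit, there is no number from which a direction could be read. The step from compound 1 to compound 3 is expected to be a step that the limit leaves unreadable from compound 1 to compound 3, that is, no change beyond the scatter. Compound 3 is estimated at 30000 nM, with a range from 10000 nM to 100000 nM, and is expected to be reported as a limit once more.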

Compound 3, half-maximal inhibitory concentration: 19600 nM
For compound 3 the middle estimate is 1.5-fold (0.18 log units) above the measured one, and the stated range covers the measured number.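

In this assay compound 3 gives 19600 nM, the first number among the compounds shown rather than a limit, so a value can now be read for a compound with a five-membered aromatic ring at this aromatic carbon of the shared core. Compound 1 gives > 20000 nM, which is a limit and not a number. Furan-3-yl in place of phenyl therefore yields an at least 1.0-fold lower number from compound 1 to compound 3 (0.00 log units; that floor lies within the scatter), and this floor is all that can be said of the change, because one end of the comparison is a limit: the limit of > 20000 nM in this assay, at which 2 of the 3 values shown sit.

The compounds shown leave open how large the true gap is, and whether the ring oxygen or the smaller ring size counts for more, since furan-3-yl differs from phenyl in both. They also leave open how thiophen-3-yl, which keeps the five-membered ring but carries sulfur in place of the oxygen, or an aminomethyl group or a carboxylic acid on the same aromatic carbon would read in this assay.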